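Swapping an aromatic ring for a saturated one

The source may report more compounds than this note shows. Statements on the series, on what has been measured and on what is new or still open speak of the compounds shown alone.

Measured so far:
Compound 1, `CCCCC(Sc1cc(OCCc2ccccc2)cc(OCCc2ccccc2)c1)C(=O)O`: in an assay on isolated protein for inhibition of Polyunsaturated fatty acid 5-lipoxygenase (Homo sapiens), read by HPLC, with a stated time of 10 min (on this read-out lower numbers stand for stronger inhibition and higher numbers for weaker inhibition), compound 1 gives 7200 nM.
Compound 2, `CCCCC(Cc1cc(OCCc2ccccc2)cc(OCCc2ccccc2)c1)C(=O)O`: in this assay compound 2 gives > 10000 nM, which is a limit of the assay and not a number.
Compound 3, `CCCC/C(=C\c1cc(OCc2ccc(C(F)(F)F)cc2)ccc1OCc1ccc(C(F)(F)F)cc1)C(=O)O`: in this assay compound 3 gives 4400 nM.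

Compound 3 has the lower of the two numbers shown, though compound 1 sits within the usual scatter of it, and compound 2 reaches only a limit. Compound 4, `CCCC/C(=C\c1cc(OCCC2CCCCC2)ccc1OCc1ccc(C(F)(F)F)cc1)C(=O)O`, is compound 3 with a single change: cyclohexylmethyl in place of 4-(trifluoromethyl)phenyl on a saturated chain carbon bound to an oxygen on an aromatic ring. Within the data shown here, the only measured step, an at least 1.3-fold higher number from compound 1 to compound 2 (0.14 log units; that floor lies within the scatter), concerns a group on an aromatic carbon of the shared core, a different kind of change from the one here, and it ends at a limit (the limit of > 10000 nM in this assay, at which 1 of the 3 values shown sits). Among the measured compounds shown here, no measured step therefore covers a swap of this sort, and nothing in the three values argues for a shift beyond the scatter in either direction. The number for compound 4 in this assay is expected close to that of compound 3, at about 6000 nM, within 2000 nM to 15000 nM. That expectation amounts to a step of a 1.4-fold higher number from compound 3 to compound 4 (0.13 log units; within the scatter).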

Compound 4, half-maximal inhibitory concentration: 10000 nM
For compound 4 the middle estimate is 1.7-fold (0.22 log units) below the measured one; the range from low to high includes it.
By their numbers in this assay, from the lowest: compounds 3, 1 and 4 (each within the scatter of the next, the first and the last beyond it).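

In this assay, a 2.3-fold higher number from compound 3 to compound 4 (0.36 log units; beyond the scatter) is the first step shown that is both a real number at each end and beyond the scatter, so this position does respond to a change of group, if modestly. The swap moves the number in the direction of weaker inhibition, but it alters several things at once: the ring stops being aromatic, the trifluoromethyl goes, and the heavy atom count falls. Compound 2 gives only a limit and not a number, and compound 4 now stands at the same figure, so the top of the range this assay reports is close: the limit of > 10000 nM in this assay, at which 1 of the 4 values shown sits.

Which of those alterations matters cannot be told from these compounds, and a plain phenyl or a 4-chlorophenyl at this place would begin to separate them. As far as these compounds go, whether an amine or a carboxylic acid on that ring would be accepted also stays open.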